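Nitro to amino: cytotoxicity notes on the series

This account rests on a few compounds, and the source may have more. Where it says the series, first, only, none or still open, it means among the compounds named here.

Compound 2 `O=[N+]([O-])c1ccc(-c2nc3cc(Cl)c(Cl)cc3[nH]2)cc1` and compound 1 `Nc1ccc(-c2nc3cc(Cl)c(Cl)cc3[nH]2)cc1` differ only in amino in place of nitro on an aromatic carbon. In an ADME assay on Vero cells (Chlorocebus sabaeus) for cytotoxicity (on this read-out lower numbers stand for higher toxicity in this test and higher numbers for lower toxicity in this test), compound 2 gives >= 100000 nM, which is a limit of the assay. Compound 1 likewise gives >= 100000 nM, again a limit. The step that the two limits leave unreadable from compound 2 to compound 1 is therefore not readable, both values sitting at the limit of >= 100000 nM in this assay, at which 2 of the 3 values shown sit.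

Within the data shown here, compound 3 `COc1ccc(-c2nc3cc(C(F)(F)F)ccc3[nH]2)c([N+](=O)[O-])c1` is the only compound with a number; in this assay compound 3 gives 20000 nM. The difference between its core and that of compound 2 is not broken down here.

Compound 4 `COc1ccc(-c2nc3cc(C(F)(F)F)ccc3[nH]2)c(N)c1` carries amino in place of nitro on an aromatic carbon. This is the same kind of change as from compound 2 to compound 1, though the place differs: ortho to a large group and meta to a methoxy group, rather than para to a large group. With the earlier step unreadable, the expectation rests only on compound 3 and its value 20000 nM. The step of a 1.5-fold higher number from compound 3 to compound 4 (0.18 log units; within the scatter) is expected to stay within the usual scatter. Compound 4 is estimated at 30000 nM, between 8000 nM and 100000 nM.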

Compound 4, half-maximal cytotoxic concentration: 50000 nM
Estimate against measurement, compound 4: 1.7-fold (0.22 log units) below; the measured number falls inside the stated range.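

In this assay, amino in place of nitro gives a 2.5-fold higher number from compound 3 to compound 4 (0.40 log units; beyond the scatter), a modest move towards lower toxicity in this test on the core of compound 3. The same change on the core of compound 2 cannot be read, because compound 2 and compound 1 both give a limit of the assay: the limit of >= 100000 nM in this assay, at which 2 of the 4 values shown sit.
So one pair on one core fixes the direction there, but does not show that the step carries over to the other core, or set a rule for the series.

Open, on these data alone, is how a nitrile or a carboxylic acid in that same place would read in this assay. Also open, as far as these compounds go, is whether the step holds on the core of compound 3 without its methoxy group.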